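From acetoxy to amino on a double-bonded nitrogen

The source may report more compounds than this note shows. Statements on the series, on what has been measured and on what is new or still open speak of the compounds shown alone.

Of the compounds shown here, two with a shared core have been read so far in a functional assay on HeLa cells (Homo sapiens) for cytotoxicity, read by XTT assay, with a stated time of 72 h (on this read-out higher numbers stand for weaker inhibition and lower numbers for stronger inhibition), as the only test. Compound 1 (`CCn1ccc2cc(/C(=N\O)c3cc(OC)c(OC)c(OC)c3)ccc21`) gives > 1000 nM as its reading, which is a limit and not a number. Compound 2 (`CCn1ccc2cc(/C(=N\OC(C)=O)c3cc(OC)c(OC)c(OC)c3)ccc21`) gives > 1000 nM as its reading, which is also only a limit. So compound 2 has no number of its own, and the one other reading beside it is a limit too.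

Compound 3 (`CCn1ccc2cc(/C(=N\N)c3cc(OC)c(OC)c(OC)c3)ccc21`) differs from compound 2 by one change, amino in place of acetoxy on a double-bonded nitrogen.

Among the measured compounds shown here, the only measured step is a step that the two limits leave unreadable from compound 1 to compound 2 and it gives no size to carry over. All the evidence amounts to the limit of > 1000 nM in this assay, at which 2 of the 2 values shown sit, and nothing more. No firm size or direction can therefore be expected in this assay for this change, though another reading at the same limit looks the likeliest outcome. The expected change is a step that the limit leaves unreadable from compound 2 to compound 3 as a loose estimate. The expected value for compound 3 is 1500 nM (estimated range 300 nM to 5000 nM).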

Compound 3, half-maximal inhibitory concentration: > 1000 nM
Compound 3 ended at the assay's limit; the forecaster's own chance of this, stated with the estimate: 70%; the middle value is on the limit's open side.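

Compound 1, compound 2 and compound 3 all sit at the same limit of the assay, so the steps among them cannot be read and give no size or direction. The compounds shown leave open how strongly any of the three acts in this assay, since none has a number of its own: the limit of > 1000 nM in this assay, at which 3 of the 3 values shown sit.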